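This account rests on a few compounds, and the source may have more. Where it says the series, first, only, none or still open, it means among the compounds named here.

Measured compounds:
Compound 1 `COc1ccc(/C=C\c2ccc3ccccc3c2)cc1[N+](=O)[O-]`: in a functional assay on P388 cells (Mus musculus) for inhibition (on this read-out lower numbers stand for stronger inhibition and higher numbers for weaker inhibition), compound 1 gives only a limit, > 20000 nM.
Compound 2 `COc1ccc(/C=C\c2ccc3ccccc3c2)cc1N`: in this assay compound 2 gives 1820 nM.
Compound 3 `COc1cc(/C=C/c2ccc(N(C)C)c([N+](=O)[O-])c2)cc(OC)c1OC`: in this assay compound 3 gives only a limit, > 5000 nM.

The change from compound 1 to compound 2 is amino in place of nitro on an aromatic carbon, and it brought an at least 10-fold lower number from compound 1 to compound 2 (1.04 log units; beyond the scatter). Compound 4 `COc1cc(/C=C/c2ccc(N(C)C)c(N)c2)cc(OC)c1OC` has not been measured; it differs from compound 3 by amino in place of nitro on an aromatic carbon, the same kind of change, though here the place is ortho to a dimethylamino group rather than ortho to a methoxy group. The difference between the two cores is not broken down here. For compound 4 a step of similar direction is expected, an at least 3.3-fold lower number from compound 3 to compound 4 (0.52 log units; beyond the scatter), resting on an at least 10-fold lower number from compound 1 to compound 2 (1.04 log units; beyond the scatter). Compound 4 is thus estimated at 1500 nM, within 300 nM to 8000 nM.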

Compound 4, half-maximal inhibitory concentration: 1520 nM
Compound 4: middle estimate off by 1.0-fold (0.01 log units), on the low side; the measured number falls inside the stated range.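

In this assay, amino in place of nitro gave an at least 3.2-fold lower number from compound 3 to compound 4 (0.51 log units; beyond the scatter), so the change points the same way on this second core as on the core of compound 1. The value of compound 3 is only a limit, > 5000 nM, and not a number. Two cores therefore show a shared direction but no reliable size, and whether the size depends on the core cannot be said: the same change on two cores in this assay, an at least 10-fold lower number (1.04 log units; beyond the scatter) from compound 1 to compound 2 and an at least 3.2-fold lower number (0.51 log units; beyond the scatter) from compound 3 to compound 4; the limit leaves it open whether they differ

As far as these compounds go, what a hydroxyl group or an acetylated amine in the same place would give in this assay remains open. From the compounds shown here alone, it is also open whether the direction of this change would hold on cores other than these two.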